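The source may hold more compounds than are shown below. What is called first, only, known or untested is meant among the compounds shown, and "the series" means these compounds.

Compound 1 `CN1C[C@H](C(=O)Nc2ccc(Br)cc2)[C@@H](c2ccc(/C=C/C(=O)Nc3ccccc3N)cc2)C1` gives 16 mL/min/kg
Compound 2 `CN1C[C@H](C(=O)NC2CC2)[C@@H](c2ccc(/C=C/C(=O)Nc3ccccc3N)cc2)C1` gives 7 mL/min/kg

Both numbers come from an in vitro ADME assay on microsomes from liver (Mus musculus) for pharmacokinetics, read by LC-MS, with a stated time of 10 min, tested at 1 uM; on this read-out higher numbers stand for fast clearance and lower numbers for slow clearance. Among the measured compounds shown here, compound 2 holds the lower of the two, and compound 1 is its only comparison. The next structure is compound 3 `CN1C[C@H](C(=O)N2CCCCC2)[C@@H](c2ccc(/C=C/C(=O)Nc3ccccc3N)cc2)C1`, which departs from compound 2 by this change: piperidin-1-yl in place of cyclopropylamino on a carbonyl carbon. In words, piperidin-1-yl stands in place of cyclopropylamino on a carbonyl carbon.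

For the measured compounds named here, only one measured step bears on this part of the molecule, and it does so indirectly: a 2.3-fold lower number from compound 1 to compound 2 (0.36 log units; beyond the scatter). That modest step came from cyclopropyl replacing 4-bromophenyl on an amide-type nitrogen. Going by the values given here, no measured pair shows an exchange that removes the amide hydrogen, as this one does, so the direction remains uncertain. Among the compounds with values here, compound 2 sits at the lower end of the numbers so far, with 7 mL/min/kg, so a modest rise is expected rather than a further fall. The estimated move is a 1.6-fold higher number from compound 2 to compound 3 (0.20 log units; within the scatter), and it may well stay within the usual scatter. For compound 3 the estimate is 11 mL/min/kg, with an expected range from 5 mL/min/kg to 25 mL/min/kg.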

Compound 3, clearance: 42 mL/min/kg
The estimate for compound 3 lay 3.8-fold (0.58 log units) below the measured number; measured number above the stated range.
By their numbers in this assay, from the lowest: compound 2; then compound 1; then compound 3.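

In this assay the group on this carbonyl carbon turns out to carry a far higher number than the earlier pair suggested, as piperidin-1-yl in place of cyclopropylamino gives a clear rise (a 6.0-fold higher number from compound 2 to compound 3 (0.78 log units; beyond the scatter)). The same group also stands above the 4-bromophenyl amide (a 2.6-fold higher number from compound 1 to compound 3 (0.42 log units; beyond the scatter)), so among these three compounds the one without the amide hydrogen has the highest number, and neither compound that keeps that hydrogen goes against this. Nothing measured here gives an explanation for this rise.

Piperidin-1-yl is the only group shown that lacks the amide hydrogen, so these compounds cannot separate the loss of that hydrogen from the change to a six-membered ring and the added heavy atoms. A cyclohexylamino group on the same carbonyl carbon, which keeps the hydrogen and carries a six-membered ring, and a dimethylamino group, which lacks the hydrogen and has no ring, would tell these two changes apart.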